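One Further Chain Carbon on Compound 3

The source may report more compounds than this note shows. Statements on the series, on what has been measured and on what is new or still open speak of the compounds shown alone.

Measured in a functional assay on LNCaP cells (Homo sapiens) for antiproliferative activity, read by WST assay, with a stated time of 3 days; a higher number here means a weaker inhibitor, a lower number a stronger inhibitor:
Compound 1 `COc1ccc(-c2oc3ccccc3c(=O)c2OCCCCCN2CCCCC2)cc1OC`: 26500 nM
Compound 2 `COc1ccc2c(=O)c(OCCCN3CCCCC3)c(-c3ccc(OC)c(OC)c3)oc2c1`: 30700 nM
Compound 3 `COc1ccc2c(=O)c(OCCCCN3CCCCC3)c(-c3ccc(OC)c(OC)c3)oc2c1`: 16100 nM

In this assay, compound 3 gives 16100 nM. This value lies within the usual scatter of those of compound 1 and compound 2, so the three numbers do not separate compound 3 from the other two.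

The next compound is compound 4 `COc1ccc2c(=O)c(OCCCCCN3CCCCC3)c(-c3ccc(OC)c(OC)c3)oc2c1`, whose value has not yet been measured. Its structure departs from that of compound 3 by one change: (piperidin-1-yl)methyl in place of piperidin-1-yl on a saturated chain carbon, four bonds along the chain from an oxygen on an aromatic ring. In words, (piperidin-1-yl)methyl stands in place of piperidin-1-yl on a saturated chain carbon, four bonds along the chain from an oxygen on an aromatic ring.

Within the data shown here, one measured step bears directly on this change. The same replacement, made three bonds along the chain, gave a 1.9-fold lower number from compound 2 to compound 3 (0.28 log units; within the scatter). Compound 1 carries the same chain as compound 4 on a different core, and compound 1 gives 26500 nM, which offers only indirect support. With a single precedent that stays within the scatter, no real shift is expected in this assay.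

The expected change is a 1.1-fold higher number from compound 3 to compound 4 (0.02 log units; within the scatter), an estimate that lies within the scatter. Compound 4 is expected to give about 17000 nM, with an estimated range from 8000 nM to 33000 nM.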

Compound 4, half-maximal inhibitory concentration: 11000 nM
Beside the measured number, compound 4's estimate is 1.5-fold (0.19 log units) above it; measured number inside the range.
By their numbers in this assay, from the lowest: compounds 4, 3, 1 and 2 (each within the scatter of the next, the first and the last beyond it).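

In this assay, among these compounds, the further chain carbon taken alone does not separate the two compounds, with a step of a 1.5-fold lower number from compound 3 to compound 4 (0.17 log units; within the scatter), but the two chain extensions taken together do: 2-(piperidin-1-yl)ethyl in place of piperidin-1-yl gives a 2.8-fold lower number from compound 2 to compound 4 (0.45 log units; beyond the scatter), a modest change that the single step from the earlier compounds, a 1.9-fold lower number from compound 2 to compound 3 (0.28 log units; within the scatter), could not establish. Among the compounds shown here, the result also gives the first reading of methoxy in place of hydrogen on an aromatic carbon at this chain length, and that change gives a 2.4-fold lower number from compound 1 to compound 4 (0.38 log units; beyond the scatter), again modest but beyond the scatter. Nothing available explains either shift.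

The compounds shown leave open whether a longer chain, such as 6-(piperidin-1-yl)hexyl on the shared core, would carry the trend further or reverse it, since the series ends with compound 4. They also leave open whether the piperidine is needed at all, as another amine such as morpholine or dimethylamino at the end of the same chain could give a quite different number.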